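From Compound 3 to Compound 4: a Chloro Substituent

The source may hold more compounds than are shown below. What is called first, only, known or untested is meant among the compounds shown, and "the series" means these compounds.

Compound 1 `C[C@]1(CN2CCc3nc(-c4ccc(F)cc4)sc3C2)Cn2cc([N+](=O)[O-])nc2O1` was tested in an ADME assay on Vero cells (Chlorocebus sabaeus) for cytotoxicity, read by MTT assay, with a stated time of 72 h (on this read-out higher numbers stand for lower toxicity in this test and lower numbers for higher toxicity in this test), and gave only a limit of the assay, > 32 ug/mL. Compound 2 `C[C@]1(CN2CCn3cc(-c4ccc(F)c(F)c4)nc3C2)Cn2cc([N+](=O)[O-])nc2O1` has no result in this assay, entered as "not determined" (no result reported). Compound 3 `C[C@]1(CN2CCc3nc(-c4ccccc4F)ccc3C2)Cn2cc([N+](=O)[O-])nc2O1` likewise gives only a limit of the assay in this assay, > 32 ug/mL. Compound 3 thus stands where compound 1 stands, and two of the three entries sit at the same limit (the limit of > 32 ug/mL in this assay, at which 2 of the 3 values shown sit). No step between measured compounds is available, so the numbers shown give no direction to build on.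

Compound 4 `C[C@]1(CN2CCc3nc(-c4ccc(Cl)cc4F)ccc3C2)Cn2cc([N+](=O)[O-])nc2O1` differs from compound 3 by chloro in place of hydrogen on an aromatic carbon. Among the compounds with values here, with no measured step to lean on, the expected change in this assay is none beyond the scatter, and compound 4 is most likely to be reported again as a limit rather than as a number. The estimate for compound 4 in this assay is 32 ug/mL, with a range from 16 ug/mL to 64 ug/mL. The implied step, a number no higher from compound 3 to compound 4 (the limit leaves the size open), is expected to remain within the scatter.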

Compound 4, half-maximal cytotoxic concentration: > 32 ug/mL
Compound 4 was reported as a limit; the forecaster's own chance of this, stated with the estimate: 75%; the middle value sits exactly at the limit.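

In this assay, within the data shown here, compound 3 and compound 4 are both reported only as limits of the assay, so no step between them can be read: the limit of > 32 ug/mL in this assay, at which 3 of the 4 values shown sit. The compounds shown leave open whether chloro in place of hydrogen shifts the read-out at all, and at what concentration any of them would reach the half-maximal cytotoxic effect.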